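The compounds below may be only part of what the source reports. "The series", "measured", "known", "first", "only" and "open" are said of these compounds alone.

Working notes on the series. In an assay on isolated protein for binding affinity to adenosine receptor A1 (Bos taurus) (a higher number here means a weaker inhibitor, a lower number a stronger inhibitor), compound 2 `CCCCNc1nc(-c2ccccc2)nc2c1nnn2Cc1ccccc1C(F)(F)F` gives 6500000 nM. Compound 1 `FC(F)(F)c1ccccc1Cn1nnc2c(NC3CCCCC3)nc(-c3ccccc3)nc21` gives 6800000 nM and compound 3 `CCCCNc1nc(-c2ccccc2)nc2c1nnn2Cc1ccccc1F` gives 4300000 nM in this assay. Compound 2 therefore stands second highest of the three numbers, with compound 1 nearest and compound 3 furthest, both gaps lying within the scatter. The step of a 1.0-fold lower number from compound 1 to compound 2 (0.02 log units; within the scatter) swaps cyclohexyl for butyl on the ring nitrogen and leaves the number where it was; the step of a 1.5-fold lower number from compound 2 to compound 3 (0.18 log units; within the scatter) swaps trifluoromethyl for fluoro and likewise stays within the scatter. Compound 4 `FC(F)(F)c1ccccc1Cn1nnc2c(NC3CCCC3)nc(-c3ccccc3)nc21` has not yet been measured in this assay. It differs from compound 2 by cyclopentyl in place of butyl on a nitrogen on an aromatic ring. Within the data shown here, the only measured step that touches this position is the one in which cyclohexyl and butyl gave the same number, so a cyclopentyl at the same nitrogen is expected to sit in the same range, and the expected step is no change at the digits printed from compound 2 to compound 4 (within the scatter). Compound 4 is estimated at 6500000 nM in this assay, with a range from 3000000 nM to 14000000 nM.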

Compound 4, inhibition constant: 600000 nM
Beside the measured number, compound 4's estimate is 11-fold (1.03 log units) above it, and the stated range ends above it.
By their numbers in this assay, from the lowest: compound 4; then compounds 3, 2 and 1 (each within the scatter of the next).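

In this assay the group on the nitrogen on the aromatic ring proves able to move the number: cyclopentyl in place of butyl gives an 11-fold lower number from compound 2 to compound 4 (1.03 log units; beyond the scatter), and cyclopentyl in place of cyclohexyl gives an 11-fold lower number from compound 1 to compound 4 (1.05 log units; beyond the scatter). The earlier step between cyclohexyl and butyl lay within the scatter, so that pair alone gave no sign of this sensitivity, and the presence of a ring does not account for the result, as cyclohexyl also carries one yet stays within the scatter of butyl. Nothing at hand bears on what lies behind the difference. On these data alone, how cyclobutyl, cycloheptyl or isopropyl on the same nitrogen would compare with cyclopentyl stays open. Also open, as far as these compounds go, is whether the cyclopentyl step would carry over with fluoro in place of trifluoromethyl on the aromatic carbon.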